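A Further Stereoisomer in a Cytotoxicity Test

This account rests on a few compounds, and the source may have more. Where it says the series, first, only, none or still open, it means among the compounds named here.

Compound 1 `CC(C)C[C@@H](NC(=O)OC(C)(C)C)C(=O)N1CCC[C@H]1C(=O)N1[C@H](C(=O)OCc2ccccc2)[C@H]1C(=O)OCc1ccccc1`, compound 2 `CC(C)C[C@H](NC(=O)OC(C)(C)C)C(=O)N1CCC[C@H]1C(=O)N1[C@@H](C(=O)OCc2ccccc2)[C@@H]1C(=O)OCc1ccccc1` and compound 3 `CC(C)C[C@@H](NC(=O)OC(C)(C)C)C(=O)N1CCC[C@@H]1C(=O)N1[C@H](C(=O)OCc2ccccc2)[C@H]1C(=O)OCc1ccccc1` have the same atoms and bonds and differ only in configuration as drawn. All three were tested in a functional assay on J774 cells (Mus musculus) for cytotoxicity, with a stated time of 48 h; on this read-out lower numbers stand for stronger inhibition and higher numbers for weaker inhibition. Compound 1 gives > 100000 nM, which is a limit of the assay. Compound 2 gives > 125000 nM, also a limit. Compound 3 gives > 100000 nM, again a limit, so it stands on no exact number.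

Compound 4 `CC(C)C[C@H](NC(=O)OC(C)(C)C)C(=O)N1CCC[C@H]1C(=O)N1[C@H](C(=O)OCc2ccccc2)[C@H]1C(=O)OCc1ccccc1` changes only the drawn configuration: the two compounds have the same atoms and bonds and differ only in configuration as drawn: 2 of 4 stereo elements differ; a stereocentre at a saturated chain carbon is drawn R in compound 3 and S in compound 4; a stereocentre at a saturated ring carbon is drawn R in compound 3 and S in compound 4.

Among the compounds with values here, three measured steps bear on this change: a step that the two limits leave unreadable from compound 1 to compound 3, a step that the two limits leave unreadable from compound 1 to compound 2 and a step that the two limits leave unreadable from compound 2 to compound 3. None has a readable size, and none of these changes in configuration produced an exact number in this assay. No step beyond the scatter is therefore expected, in either direction. The expected change is a step that the limit leaves unreadable from compound 3 to compound 4. For compound 4 the estimate is 120000 nM, with an expected range of 60000 nM to 200000 nM, and a report of only a limit is the likeliest outcome.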

Compound 4, half-maximal inhibitory concentration: > 125000 nM
Compound 4 gave a limit, no number (the forecaster's own chance of this, stated with the estimate: 85%); middle value at least 1.0-fold (0.01 log units) away from the limit.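

In this assay compound 4 gives > 125000 nM, which is a limit of the assay. Within the data shown here, compound 1, compound 2 and compound 3 also sit at limits, so no step to compound 4 can be read. As far as these compounds go, whether configuration changes cytotoxicity here stays open: none of the four compounds gives an exact number.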